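Swapping the furan amide for a methoxyphenoxy ether

The source may report more compounds than this note shows. Statements on the series, on what has been measured and on what is new or still open speak of the compounds shown alone.

In a functional assay on PANC-1 cells (Homo sapiens) for inhibition, read by MTT assay, with a stated time of 24 h, tested at 10 uM (on this read-out higher numbers stand for more inhibition at the one concentration tested (going by the name of the read-out) and lower numbers for less inhibition), compound 2 `CC(C)=CCC/C(C)=C/CC1Cc2c(OCCCNC(=O)c3ccco3)cc(=O)n(CCCO)c2CC1(C)C` gives 2.8%, and compound 1 `CC(C)=CCC/C(C)=C/CC1Cc2c(OCCCNS(=O)(=O)c3ccc(Br)cc3)cc(=O)n(CCCO)c2CC1(C)C` gives 0%; the step of a number 2.8 percentage points higher from compound 1 to compound 2 (within the scatter) lies within the scatter, so compound 2 stands alongside compound 1 rather than apart from it. Compound 3 `COc1ccc(OCCCOc2cc(=O)n(CCCO)c3c2CC(C/C=C(\C)CCC=C(C)C)C(C)(C)C3)cc1` differs from compound 2 by 4-methoxyphenoxy in place of ((furan-2-yl)carbonyl)amino on a saturated chain carbon, three bonds along the chain from an oxygen on an aromatic ring. Within the data shown here, no measured step covers this change; the one known step, exchanging the group on the amine nitrogen, stayed within the scatter, so the expected step is a number 0.2 percentage points higher from compound 2 to compound 3 (within the scatter), not reaching beyond the scatter. Compound 3 is therefore estimated at 3%, within 0% to 13%.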

Compound 3, a percentage reported as inhibition, at one concentration (the size of the read-out at that concentration, not a potency): 0%
Compound 3: the middle estimate sits 3 percentage points above what was measured; measured number inside the range.
By their numbers in this assay, from the lowest: compounds 1, 3 and 2 (each within the scatter of the next).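

Putting 4-methoxyphenoxy in place of ((furan-2-yl)carbonyl)amino gives a number 2.8 percentage points lower from compound 2 to compound 3 (within the scatter), and putting it in place of ((4-bromophenyl)sulfonyl)amino gives no change at the digits printed from compound 1 to compound 3 (within the scatter). At this spot on the chain, a group with no nitrogen and no hydrogen-bond donors therefore stands alongside both earlier groups in this assay, so three quite different end groups cannot be told apart here. No measurement offers an explanation for this. On these data alone, whether an amine or a carboxylic acid at this chain end would move the number beyond the scatter remains open.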